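The source may hold more compounds than are shown below. What is called first, only, known or untested is meant among the compounds shown, and "the series" means these compounds.

Three compounds of a shared saturated ring system are measured in an ADME assay (Gallus gallus) for cytotoxicity, read by microscopy, with a stated time of 24 h; a higher number here means that more compound is tolerated, a lower number that less compound is tolerated. Compound 1 `BrC12CCCC3CC(CCC31)C2` gives in this assay no result reported. Compound 3 `O=C1C2CCC3C(CCCC13)C2` carries a carbonyl, and in this assay compound 3 gives 2400000 nM. Compound 2 `O[C@H]1C2CCCC3C[C@H]1CC[C@H]32` carries a hydroxyl in place of that carbonyl, and in this assay compound 2 gives 1800000 nM. The two numbers lie within the usual scatter of each other, so neither compound can be said to be tolerated better than the other.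

Compound 4 `O[C@@H]1C2CCCC3C[C@@H]1CC[C@@H]32` is the next compound to be measured. Its difference from compound 2 is the two compounds have the same atoms and bonds; at least one stereo element is drawn with a configuration in one of them and without one in the other: 3 of 5 stereo elements differ; a stereocentre at a saturated ring carbon is drawn R in compound 2 and S in compound 4; a stereocentre at a saturated ring carbon is drawn R in compound 2 and S in compound 4; a stereocentre at a saturated ring carbon is drawn R in compound 2 and S in compound 4. Going by the values given here, no step between two measured compounds with the same kind of change is available, so the size of this step is an open question. Since the atoms and bonds are identical and only the drawn configuration differs, the expectation is that the step from compound 2 to compound 4 in this assay, no change at the digits printed from compound 2 to compound 4 (within the scatter), stays within the scatter. Compound 4 is therefore expected to give about 1800000 nM, with a range from 900000 nM to 3600000 nM.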

Compound 4, minimum cytotoxic concentration: 750000 nM
The estimate for compound 4 lay 2.4-fold (0.38 log units) above the measured number; measured number below the stated range.
By their numbers in this assay, from the lowest: compound 4; then compounds 2 and 3 (each within the scatter of the next).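

The reading in this assay shows a 2.4-fold lower number from compound 2 to compound 4 (0.38 log units; beyond the scatter) even though no atom or bond changes, so a difference in drawn configuration alone goes with a shift beyond the scatter. The earlier compounds shown here could not show this, since compound 2 and compound 3 differ in their oxygen group and their numbers lie within the scatter of each other. This step therefore makes compound 4 less well tolerated than compound 2, with one caution on how firmly the change can be tied to configuration: the fact that one of compounds 2 and 4 is drawn with a defined configuration and the other without, at the place where they differ.

The compounds shown leave open whether a step of this size would recur with the hydroxyl replaced by another group, such as an amine or a carboxylic acid. On these data alone, compound 1 has no result to compare, so the effect of its bromine on tolerance also remains unknown.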